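This account rests on a few compounds, and the source may have more. Where it says the series, first, only, none or still open, it means among the compounds named here.

Three hydrazones sharing one core have been measured in a functional assay (Mus musculus, strain BALB/C) for inhibition, read by MTT assay, with stated times of 24 h and 72 h; on this read-out higher numbers stand for weaker inhibition and lower numbers for stronger inhibition. Compound 1 `Cc1ccc(C(=O)N/N=C/c2ccccc2)c(O)c1` gives 53900 nM, compound 3 `Cc1ccc(C(=O)N/N=C/c2ccc(Cl)cc2Cl)c(O)c1` gives 9780 nM, and compound 2 `Cc1ccc(C(=O)N/N=C/c2cc(Cl)cc(Cl)c2O)c(O)c1` gives 1510 nM, the lowest of the three numbers: compound 3 sits nearest to it, and the gaps to both compound 3 and compound 1 lie beyond the scatter, so compound 2 is the strongest inhibitor measured so far. Compound 4 `Cc1ccc(C(=O)N/N=C/c2cc(Cl)ccc2O)c(O)c1` is yet to be measured in this assay. It differs from compound 2 in one place: hydrogen in place of chloro on an aromatic carbon. Since compound 1 gives 53900 nM with no chloro at all, a moderate weakening is expected from compound 2 to compound 4, a 2.3-fold higher number from compound 2 to compound 4 (0.37 log units; beyond the scatter) in this assay. Compound 4 is therefore estimated at 3500 nM, within 1200 nM to 10000 nM.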

Compound 4, half-maximal inhibitory concentration: 1290 nM
Beside the measured number, compound 4's estimate is 2.7-fold (0.43 log units) above it, and the stated range covers the measured number.
By their numbers in this assay, from the lowest: compounds 4 and 2 (each within the scatter of the next); then compound 3; then compound 1.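

In this assay, hydrogen in place of chloro on this aromatic carbon, ortho to a hydroxy group, gives a 1.2-fold lower number from compound 2 to compound 4 (0.07 log units; within the scatter). The earlier compounds shown here could not show this: with the other chloro group in place, the number does not depend on a chloro group at this position. Nothing measured here explains this result. The compounds shown leave open whether a larger group at this position, such as a methoxy group, an amine or a carboxylic acid, would move the number. They also leave open what removing the remaining chloro group would do on its own.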